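Trifluoroacetyl pyrrole lactones: cytotoxicity notes, diastereomer pair

The compounds below may be only part of what the source reports. "The series", "measured", "known", "first", "only" and "open" are said of these compounds alone.

Measured so far:
- compound 1, `C#CC[C@H]1C[C@H](n2cccc2C(=O)CC)C(=O)O1`: 40700 nM
- compound 2, `C#CC[C@@H]1C[C@H](n2cccc2C(=O)C(F)(F)F)C(=O)O1`: > 100000 nM

Compound 1 carries a propanoyl group on the pyrrole and, in an ADME assay on N2a cells (Mus musculus) for cytotoxicity, read by MTT assay (a higher number here means a weaker inhibitor, a lower number a stronger inhibitor), compound 1 gives 40700 nM. Compound 2 carries a trifluoromethyl ketone in its place and differs from compound 1 also at a ring stereocentre, so the two are not a single-change pair. For compound 2 only a limit is known: in this assay compound 2 reads > 100000 nM, which is the limit of the measurement and not a number (the limit of > 100000 nM in this assay, at which 1 of the 2 values shown sits).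

Compound 3, `C#CC[C@H]1C[C@H](n2cccc2C(=O)C(F)(F)F)C(=O)O1`, is the remaining diastereomer: the two compounds have the same atoms and bonds and differ only in configuration as drawn: 1 of 2 stereo elements differ; a stereocentre at a saturated ring carbon is drawn R in compound 2 and S in compound 3; the ring stereocentre drawn R in compound 2 is drawn S in compound 3. Among the compounds with values here, no measured step of this kind is available, so no direction can be assigned from data. Inversion of one saturated ring stereocentre is expected to give a step of an at least 1.4-fold lower number from compound 2 to compound 3 (0.15 log units; that floor lies within the scatter), small and within the usual scatter. Compound 3 is therefore estimated at 70000 nM, with a likely range from 30000 nM to 160000 nM, and a fair chance that only a limit is again reported.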

Compound 3, half-maximal inhibitory concentration: 97800 nM
Beside the measured number, compound 3's estimate is 1.4-fold (0.15 log units) below it, and the stated range covers the measured number.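

Compound 3 gives a number rather than a limit for a trifluoromethyl ketone in this assay, so the change at the carbonyl can now be read on a single ring configuration: trifluoromethyl in place of ethyl gives a 2.4-fold higher number from compound 1 to compound 3 (0.38 log units; beyond the scatter). Swapping this group therefore weakens the cytotoxicity read-out only to a limited extent, though the step does lie beyond the usual scatter. At the ring stereocentre the result is an at least 1.0-fold lower number from compound 2 to compound 3 (0.00 log units; that floor lies within the scatter), which shows no separation between the two diastereomers on this read-out and gives no direction for the configuration, with the step resting on one change alone: the fact that compounds 2 and 3 differ only in the configuration as drawn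

Going by these compounds, the size of any effect of the ring configuration remains open, as does whether the step at the carbonyl holds on the other ring configuration. Also open, on these data alone, is how a longer chain on the carbonyl, or a carboxylic acid in place of the ketone, would read in this assay.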